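Amide Nitrogen Substituent Change Followed by Paw Edema

The compounds below may be only part of what the source reports. "The series", "measured", "known", "first", "only" and "open" are said of these compounds alone.

For the measured compounds named here, compound 1 `CCCCNC(=O)c1c(O)c2cccnc2n(-c2ccccc2)c1=O` gives 12.8% in a functional assay on the whole organism for inhibition, with Rattus norvegicus as the target, read by paw edema, at a dose of 100 mg/kg by the oral route (on this read-out higher numbers stand for more inhibition at the one dose given (going by the name of the read-out) and lower numbers for less inhibition), one of only two numbers available; the nearest is compound 2 `O=C(Nc1ccc(Cl)cc1)c1c(O)c2cccnc2n(-c2ccccc2)c1=O`, which gives 11.6%. The step of a number 1.2 percentage points lower from compound 1 to compound 2 (within the scatter) lies within the scatter. Compound 3 `O=C(Nc1ccc(Cl)nc1)c1c(O)c2cccnc2n(-c2ccccc2)c1=O` differs from compound 1 by 6-chloropyridin-3-yl in place of butyl on an amide-type nitrogen. Going by the values given here, the one measured step that bears on this change, the replacement of butyl by 4-chlorophenyl, produced no shift beyond the scatter, so no step beyond the scatter is expected here either. Compound 3 is expected to show a number 0.8 percentage points lower from compound 1 to compound 3 (within the scatter). The estimated value of compound 3 is 12%, ranging from 2% to 24%.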

Compound 3, a percentage reported as inhibition, in the whole organism at one dose (the size of the read-out at that dose, not a potency): 9.2%
The estimate for compound 3 lay 2.8 percentage points above the measured number, and the stated range covers the measured number.
By their numbers in this assay, from the lowest: compounds 3, 2 and 1 (each within the scatter of the next).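

Placing 6-chloropyridin-3-yl on the amide-type nitrogen gives, in this assay, a number 3.6 percentage points lower from compound 1 to compound 3 (within the scatter), while exchanging 4-chlorophenyl for the same group gives a number 2.4 percentage points lower from compound 2 to compound 3 (within the scatter). An aromatic ring with a hetero atom therefore joins butyl and 4-chlorophenyl within the scatter, so this read-out does not separate the three groups at this place. No evidence explaining this result is available. Going by these compounds, whether a carboxylic acid, an amine or a chain longer than butyl on this nitrogen would move the number beyond the scatter remains open.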